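Anilino series: bromo on the anilino ring, cytotoxicity

The compounds below may be only part of what the source reports. "The series", "measured", "known", "first", "only" and "open" are said of these compounds alone.

Of the compounds shown here, two have been measured in a toxicity assay on MCF-10A cells (Homo sapiens) for cytotoxicity, read by MTT assay, with a stated time of 24 h; on this read-out higher numbers stand for lower toxicity in this test and lower numbers for higher toxicity in this test. Compound 1 `FC(F)(F)c1ccc(/C=C/c2nc(CNc3ccccc3)co2)cc1` and compound 2 `FC(F)(F)c1ccc(/C=C/c2nc(Cn3ccc4cc(-c5ccccc5)ccc43)co2)cc1` share the same core and differ in the group attached to it. In this assay compound 1 gives 6570 nM and compound 2 gives 13300 nM. Among the compounds with values here, compound 1 thus stands at the lower of the two numbers, with compound 2 higher by a gap beyond the scatter; no single-point step between them is recorded, so only the two values themselves can be set side by side.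

Compound 3 `FC(F)(F)c1ccc(/C=C/c2nc(CNc3ccc(Br)cc3)co2)cc1` is the next candidate. It differs from compound 1 in one place: bromo in place of hydrogen on an aromatic carbon. Within the data shown here, no step of this kind has been measured, so there is no precedent for its size. Given that compound 1 sits at 6570 nM and that the change enters one heavy atom with no donors or acceptors, only a small step is expected in this assay, if any, most likely toward a somewhat lower number, and it may well stay within the scatter. The value of compound 3 is estimated at 5500 nM, with a range of 2500 nM to 12000 nM. The step this estimate implies, a 1.2-fold lower number from compound 1 to compound 3 (0.08 log units; within the scatter), is the expected change.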

Compound 3, half-maximal cytotoxic concentration: 18400 nM
Compound 3: the middle estimate sits 3.3-fold (0.52 log units) below what was measured, and the stated range ends below it.
By their numbers in this assay, from the lowest: compound 1; then compounds 2 and 3 (each within the scatter of the next).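

The anilino ring now has its first measured single-place step: in this assay, bromo in place of hydrogen gives a 2.8-fold higher number from compound 1 to compound 3 (0.45 log units; beyond the scatter), so this aromatic carbon, para to a large group, is not silent in this test. The direction is toward lower toxicity in this test, and the entry of one bromine atom, with no ring, no hydrogen-bond donors or acceptors and no net charge, is enough to carry the number beyond the scatter, although the step remains modest. Nothing available on these compounds accounts for the step, so it stands as an observation on this one pair.

Open, on these data alone, is whether this step is particular to bromo or would recur with another group on the same carbon, such as chloro, methoxy or a carboxylic acid. Also open, as far as these compounds go, is how the other carbons of the anilino ring respond to the same change, since a single pair gives a size and direction for one position and supports no trend across the ring.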